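Side chains on a shared core: a step hidden by limits

The source may report more compounds than this note shows. Statements on the series, on what has been measured and on what is new or still open speak of the compounds shown alone.

Measured so far in a functional assay on SH-SY5Y cells (Homo sapiens) for cytotoxicity, read by MTT assay, with a stated time of 72 h; a higher number here means a weaker inhibitor, a lower number a stronger inhibitor
compound 1 (`O=C1c2c[n+]([O-])c3ccccc3c2C(=O)c2c1c1ccccc1n2Cc1cn([C@H]2O[C@H](CO)[C@@H](O)[C@H]2O)nn1`) gives 1340 nM
compound 2 (`O=C1c2c[n+]([O-])c3ccccc3c2C(=O)c2c1c1ccccc1n2Cc1cn(CC(O)CO)nn1`) gives > 1000 nM
compound 3 (`CC1(C)O[C@@H](CO)[C@H](Cn2cc(Cn3c4c(c5ccccc53)C(=O)c3c[n+]([O-])c5ccccc5c3C4=O)nn2)O1`) gives > 1000 nM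

Compound 2 gives > 1000 nM which is a limit and not a number. Compound 3 shares it, and the evidence is the limit of > 1000 nM in this assay, at which 2 of the 3 values shown sit, only.

Compound 4 (`CN1CCN(CCCn2c3c(c4ccccc42)C(=O)c2c[n+]([O-])c4ccccc4c2C3=O)CC1`) carries 2-(4-methylpiperazin-1-yl)ethyl in place of 1-(2,3-dihydroxypropyl)-1H-1,2,3-triazol-4-yl (2-(4-methylpiperazin-1-yl)ethyl in place of 1-(2,3-dihydroxypropyl)-1H-1,2,3-triazol-4-yl on a saturated chain carbon bound to an aromatic nitrogen) on a saturated chain carbon bound to an aromatic nitrogen.

The nearest evidence is a step that the limit leaves unreadable from compound 1 to compound 2 and a step that the two limits leave unreadable from compound 2 to compound 3 and a step that the limit leaves unreadable from compound 1 to compound 3 and none of these has a readable size. Within the data shown here, the only true number, compound 1 at 1340 nM anchors the expectation. No step beyond the scatter is expected, in either direction, and the estimated change is a number no higher from compound 2 to compound 4 (the limit leaves the size open) for now. The expected value for compound 4 is 1000 nM with an estimated range of 300 nM to 3000 nM in this assay when measured.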

Compound 4, half-maximal inhibitory concentration: 560 nM
Compound 4: middle estimate off by 1.8-fold (0.25 log units), on the high side, and the stated range covers the measured number.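

Among these compounds, replacing 1-(2,3-dihydroxypropyl)-1H-1,2,3-triazol-4-yl with 2-(4-methylpiperazin-1-yl)ethyl on this saturated chain carbon gives the only step here with a readable floor in this assay, namely an at least 1.7-fold lower number from compound 2 to compound 4 (0.25 log units; that floor lies within the scatter). The steps among compound 1, compound 2 and compound 3 cannot be read. This new step also starts from a limit, so its full size stays unknown: the limit of > 1000 nM in this assay, at which 2 of the 4 values shown sit.

The compounds shown leave open whether the change depends on losing the triazole or on gaining the piperazine ring. A morpholine ring or a dimethylamine on the same chain would help separate these two parts.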